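Compound 4: methoxyphenyl in place of the methoxyindolyl group

The compounds below may be only part of what the source reports. "The series", "measured", "known", "first", "only" and "open" are said of these compounds alone.

Compound 3 `COc1ccc2[nH]c(-c3nn4c(COc5ccnc6cc(OC)ccc56)nnc4s3)cc2c1` gives 85.6 nM in a functional assay on EBC-1 cells (Homo sapiens) for antiproliferative activity, with a stated time of 72 h; on this read-out higher numbers stand for weaker inhibition and lower numbers for stronger inhibition. Compound 2 `COc1ccc2c(OCc3nnc4sc(-c5cc6ccccc6n5C)nn34)ccnc2c1` gives 149 nM in this assay, and the step of a 1.7-fold lower number from compound 2 to compound 3 (0.24 log units; within the scatter) leaves the two compounds within the scatter of each other, so no order between them can be read. Compound 1 `COc1ccc2c(OCc3nnc4sc(-c5cccn5C)nn34)ccnc2c1` has no result in this assay: "not determined" (no result reported). Compound 4 `COc1ccc(-c2nn3c(COc4ccnc5cc(OC)ccc45)nnc3s2)cc1` differs from compound 3 by 4-methoxyphenyl in place of 5-methoxy-1H-indol-2-yl on an aromatic carbon. For the measured compounds named here, the only measured step at this aromatic carbon, a 1.7-fold lower number from compound 2 to compound 3 (0.24 log units; within the scatter), exchanged one bicyclic group for another and stayed within the scatter; no measured step removes the five-membered aromatic ring altogether, as this change does, so the data give no direct guide to its size. A small loss beyond the scatter is expected for compound 4, since compound 3 carries the larger group with 85.6 nM and the step of a 2.9-fold higher number from compound 3 to compound 4 (0.47 log units; beyond the scatter) is estimated accordingly. Compound 4 is expected to give about 250 nM in this assay, within a range from 70 nM to 900 nM.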

Compound 4, half-maximal inhibitory concentration: 161 nM
Beside the measured number, compound 4's estimate is 1.6-fold (0.19 log units) above it; measured number inside the range.
By their numbers in this assay, from the lowest: compounds 3, 2 and 4 (each within the scatter of the next).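

this assay shows a 1.9-fold higher number from compound 3 to compound 4 (0.27 log units; within the scatter) and a 1.1-fold higher number from compound 2 to compound 4 (0.03 log units; within the scatter) and neither step can be read as a gain or a loss. The earlier compounds shown here with a number carried only bicyclic groups on this aromatic carbon, whereas compound 4 shows that 4-methoxyphenyl, a single six-membered ring with no five-membered aromatic ring and no hydrogen-bond donor, gives a number within the scatter of both. Nothing measured on these compounds bears on the reason for this result.

As far as these compounds go, every compound with a number here carries an aromatic group at this carbon, so whether an amine, a carboxylic acid or a longer alkyl chain would stay within the same range remains open. Also open, from the compounds shown here alone, is whether plain phenyl would match 4-methoxyphenyl, which would show how much the methoxy group contributes at this position.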